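The compounds below may be only part of what the source reports. "The series", "measured", "known", "first", "only" and "open" are said of these compounds alone.

Compound 1 `CCCCC(=O)Nc1ccn([C@@H]2CO[C@H](CO)O2)c(=O)n1` carries a butyl chain on the carbonyl carbon of its amide. For the measured compounds named here, in a functional assay on A549 cells (Homo sapiens) for cytotoxicity, read by sulforhodamine B assay, with a stated time of 72 h (on this read-out higher numbers stand for weaker inhibition and lower numbers for stronger inhibition), compound 1 gives 5230 nM, the highest of the two numbers measured so far. Going by the values given here, its only measured neighbour is compound 2 `CCCCCCCCCCCC(=O)Nc1ccn([C@@H]2CO[C@H](CO)O2)c(=O)n1`, which in this assay gives 15 nM; the step of a 350-fold lower number from compound 1 to compound 2 (2.54 log units; beyond the scatter) is large and beyond the scatter. Compound 3 `O=C(Nc1ccn([C@@H]2CO[C@H](CO)O2)c(=O)n1)c1ccc(Cl)cc1Cl` has not yet been measured. It differs from compound 1 in one place: 2,4-dichlorophenyl in place of butyl on a carbonyl carbon. Among the compounds with values here, the one measured step bears only loosely on this change, since it lengthened the chain rather than replacing it with a ring, yet it shows the direction in which the single enlargement at this carbonyl carbon moved the number. Because the step of a 350-fold lower number from compound 1 to compound 2 (2.54 log units; beyond the scatter) was so large, some movement in the same direction is expected here, though a smaller one, since the entering group is a smaller addition than heptyl was; the expected step is a 3.5-fold lower number from compound 1 to compound 3 (0.54 log units; beyond the scatter). Compound 3 is therefore estimated at 1500 nM in this assay, within a range from 200 nM to 8000 nM.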

Compound 3, half-maximal inhibitory concentration: 9830 nM
Compound 3: middle estimate off by 6.6-fold (0.82 log units), on the low side; measured number above the stated range.
By their numbers in this assay, from the lowest: compound 2; then compounds 1 and 3 (each within the scatter of the next).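

In this assay, the step of a 1.9-fold higher number from compound 1 to compound 3 (0.27 log units; within the scatter) means that 2,4-dichlorophenyl in place of butyl on a carbonyl carbon, a change that brings in a six-membered aromatic ring of carbon only and two chlorine atoms, gives no difference that can be told from the scatter. This position therefore does not respond in the same way to every larger group: the earlier step of a 350-fold lower number from compound 1 to compound 2 (2.54 log units; beyond the scatter) was large, whereas replacing the butyl chain with this ring leaves the number of compound 3 within the scatter of that of compound 1. Nothing measured here accounts for the contrast between these two steps.

The compounds shown leave open how the number changes along the chain between butyl and the longer chain of compound 2, for example with octyl or decyl, and whether it falls gradually or only at a certain length. They also leave open whether a plain phenyl, a benzyl or a 4-chlorophenyl group at this carbonyl carbon would behave like 2,4-dichlorophenyl, so the ring and its chlorine atoms cannot be judged separately.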